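Replacing the sulfonamide with a nonyl chain on the shared core

A few compounds are considered here, and "the series" means these few. Any claim that something is new, unique, unknown or untested is made for them only; others in the source may bear on it.

Of the compounds shown here, three built on the same core have been tested in a functional assay on HeLa cells (Homo sapiens) for antiproliferative activity, read by MTT assay, with a stated time of 72 h; on this read-out higher numbers stand for weaker inhibition and lower numbers for stronger inhibition. Compound 1 `O=C1O[C@H]([C@@H](O)Cn2cc(CNS(=O)(=O)c3ccc(Cl)cc3F)nn2)C(OCc2ccccc2)=C1OCc1ccccc1` gives 20700 nM. Compound 2 `COc1ccc(-c2cn(C[C@H](O)[C@H]3OC(=O)C(OCc4ccccc4)=C3OCc3ccccc3)nn2)cc1` gives 16400 nM. Compound 3 `O=C1O[C@H]([C@@H](O)Cn2cc(CNS(=O)(=O)c3ccc(Cl)cc3)nn2)C(OCc2ccccc2)=C1OCc1ccccc1` gives 13600 nM, the lowest of the three numbers, though its gaps to both others are within the scatter: a 1.5-fold lower number from compound 1 to compound 3 (0.18 log units; within the scatter) and a 1.2-fold lower number from compound 2 to compound 3 (0.08 log units; within the scatter).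

Compound 4 `CCCCCCCCCCc1cn(C[C@H](O)[C@H]2OC(=O)C(OCc3ccccc3)=C2OCc2ccccc2)nn1` has not yet been measured in this assay. It differs from compound 3 at one place: nonyl in place of ((4-chlorophenyl)sulfonyl)amino on a saturated chain carbon bound to an aromatic carbon

Going by the values given here, two measured steps bear on this change, both touching the same arm of the molecule. The step from compound 1 to compound 3 exchanged fluoro for hydrogen and the step from compound 2 to compound 3 exchanged 4-methoxyphenyl for the sulfonamide-bearing group; neither moved the number beyond the scatter. The exchange in compound 4 is larger than either, since a whole ring and the sulfonamide give way to a plain chain, but the evidence so far shows this arm tolerating quite different groups with little change in the number. Compound 4 is therefore expected to land near its parent, with a 1.2-fold lower number from compound 3 to compound 4 (0.09 log units; within the scatter) as the estimated step, and an estimated value of 11000 nM, with a range from 3500 nM to 35000 nM.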

Compound 4, half-maximal inhibitory concentration: 22900 nM
The estimate for compound 4 lay 2.1-fold (0.32 log units) below the measured number; the measured number falls inside the stated range.
By their numbers in this assay, from the lowest: compounds 3, 2, 1 and 4 (each within the scatter of the next).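

In this assay, going by these compounds alone, the earlier compounds kept an aromatic ring on this arm, whereas compound 4 shows that a plain chain with no ring, no hydrogen-bond donors and no hydrogen-bond acceptors can also stand there, with nonyl in place of ((4-chlorophenyl)sulfonyl)amino giving a 1.7-fold higher number from compound 3 to compound 4 (0.23 log units; within the scatter). The other two comparisons agree, with a 1.1-fold higher number from compound 1 to compound 4 (0.04 log units; within the scatter) when the fluorinated sulfonamide gives way to nonyl and a 1.4-fold higher number from compound 2 to compound 4 (0.14 log units; within the scatter) when decyl replaces 4-methoxyphenyl on an aromatic carbon, so among these four compounds neither the sulfonamide nor an aromatic ring on this arm is needed for a number in this range. No supporting measurement is available to explain this tolerance.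

On these data alone, it remains open whether any group at this place can move the number beyond the scatter, and a primary amine, a carboxylic acid or a much shorter chain such as butyl would test that. As far as these compounds go, it is also open whether the numbers depend on the two benzyloxy groups of the shared core, since all four compounds carry them unchanged.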